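A chlorine added to the shared core of compound 1

The source may hold more compounds than are shown below. What is called first, only, known or untested is meant among the compounds shown, and "the series" means these compounds.

Of the compounds shown here, three have been measured in a functional assay on MDA-MB-231 cells (Homo sapiens) for cytotoxicity, read by sulforhodamine B assay, with a stated time of 48 h; on this read-out higher numbers stand for weaker inhibition of growth and lower numbers for stronger inhibition of growth. Compound 1 `Cc1ccc2nc(/N=C3\C(=O)N(CN4CCCCC4)c4ccccc43)sc2c1` gives 34500 nM. Compound 2 `Cc1ccc2nc(/N=C3\C(=O)N(CN(C)C)c4ccccc43)sc2c1` gives 19200 nM, and compound 3 `CCN(CC)CN1C(=O)C(=O)c2c(Cl)cccc21`, built on a different core, gives 44500 nM. Compound 1 thus stands second highest of the three numbers, with both neighbours within the usual scatter of it.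

Within the data shown here, the only step between measured compounds, a 1.8-fold lower number from compound 1 to compound 2 (0.25 log units; within the scatter), changes the amine on the chain bound to the ring nitrogen, not the aromatic ring, and stays within the scatter.

Compound 4 `Cc1ccc2nc(/N=C3\C(=O)N(CN4CCCCC4)c4cccc(Cl)c43)sc2c1` differs from compound 1 by chloro in place of hydrogen on an aromatic carbon. Among the measured compounds shown here, no measured step makes this change; compound 3 carries a chloro on its aromatic ring but on another core, so its value only shows where such a ring substituent has been seen. With nothing pointing to a large shift, the step from compound 1 to compound 4 is expected to be small, a 1.2-fold lower number from compound 1 to compound 4 (0.06 log units; within the scatter), in this assay. Compound 4 is therefore estimated at 30000 nM, in a range from 12000 nM to 75000 nM.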

Compound 4, concentration for 50% growth inhibition: 55800 nM
Compound 4: the middle estimate sits 1.9-fold (0.27 log units) below what was measured; the measured number falls inside the stated range.
By their numbers in this assay, from the lowest: compounds 2, 1, 3 and 4 (each within the scatter of the next, the first and the last beyond it).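

In this assay, chloro in place of hydrogen on an aromatic carbon of the shared core gives a 1.6-fold higher number from compound 1 to compound 4 (0.21 log units; within the scatter), so this change cannot be told apart from repeat measurement. Among these compounds, the earlier step altered only the amine on the chain, so this is the first look at a substituent on the aromatic ring of this core, and at this place, ortho to a fused ring and meta to a fused ring, chloro leaves the number within the scatter of compound 1. No measurement on hand offers an explanation for this small step.

As far as these compounds go, it remains open whether a methoxy group or an amine at this same place would give a step beyond the scatter. From the compounds shown here alone, it is also open whether chloro would give a similar step with the dimethylamino chain of compound 2.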